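This account rests on a few compounds, and the source may have more. Where it says the series, first, only, none or still open, it means among the compounds named here.

Compound 1 `C=C1C[C@]23C[C@@]1(O)CC[C@H]2c1ccc(OS(=O)(=O)c2ccc(C)cc2)c(C)c1[C@@H]3Cn1cc(-c2ccc(Cl)cc2)nn1` and compound 2 `C=C1C[C@]23C[C@@]1(O)CC[C@H]2c1ccc(OS(=O)(=O)c2ccc(C)cc2)c(C)c1[C@@H]3Cn1cc(-c2ccc(F)cc2)nn1` share the same core and differ in a single ring substituent. In a functional assay on HL-60 cells (Homo sapiens) for cytotoxicity, read by MTT assay, with a stated time of 4 days (a lower number here means a stronger inhibitor, a higher number a weaker inhibitor), compound 1 gives no number, only the limit of the assay, > 20000 nM. In this assay compound 2 likewise gives only a limit, > 20000 nM. The step that the two limits leave unreadable from compound 1 to compound 2 therefore cannot be sized, because both values sit at the limit of > 20000 nM in this assay, at which 2 of the 2 values shown sit. That is where compound 2 stands: at the limit, with nothing known about its strength below it.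

Compound 3 `C=C1C[C@]23C[C@@]1(O)CC[C@H]2c1ccc(OS(=O)(=O)c2ccc(C)cc2)c(C)c1[C@@H]3Cn1cc(-c2ccccn2)nn1` has not yet been measured. Compared with compound 2, the difference is pyridin-2-yl in place of 4-fluorophenyl on an aromatic carbon. Among the compounds with values here, no measured step of readable size bears on this change; the only measured step, from compound 1 to compound 2, is unreadable, and both measured compounds stay at the limit of this assay. The expectation for compound 3 is that it also remains weak. The step that this estimate means, a step that the limit leaves unreadable from compound 2 to compound 3, is expected to lie within the scatter. Compound 3 is estimated at 25000 nM, within a range from 8000 nM to 80000 nM, most likely reported once more only as a limit.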

Compound 3, half-maximal inhibitory concentration: > 20000 nM
Compound 3: a limit, no number; the forecaster's own chance of this, stated with the estimate: 85%; the middle value lies beyond the limit too.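

Within the data shown here, compound 3 joins compound 1 and compound 2 without a number, so no step between these three compounds can be read, because all of them stop at the same limit: the limit of > 20000 nM in this assay, at which 3 of the 3 values shown sit. Still open, from the compounds shown here alone, is how strong each compound really is in this assay, and whether 4-chlorophenyl, 4-fluorophenyl or pyridin-2-yl makes any difference there.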